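A few compounds are considered here, and "the series" means these few. Any claim that something is new, unique, unknown or untested is made for them only; others in the source may bear on it.

Of the compounds shown here, three of one series have so far been tested in a functional assay on NCI-H460 cells (Homo sapiens) for inhibition, read by MTT assay; on this read-out higher numbers stand for weaker inhibition and lower numbers for stronger inhibition. Compound 1 `N#Cc1c(N)sc(C(=O)Nc2ccc(Cl)cc2)c1-c1ccccc1` gives 760 nM in this assay. Compound 2 `N#CCC(=O)Nc1sc(C(=O)Nc2ccc(Cl)cc2)c(-c2ccccc2)c1C#N` gives 1040 nM in this assay. Compound 3 `CCOC(=O)c1c(NC(=O)CC#N)sc(C(=O)Nc2ccccc2)c1-c1ccccc1` gives 490 nM in this assay, the lowest of the three numbers, though its gap to compound 1 lies within the scatter and only its gap to compound 2 lies beyond it. The difference between the core of compound 2 and the core of compound 3 is not broken down here.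

The change from compound 2 to compound 1 is hydrogen in place of (cyanomethyl)carbonyl on a nitrogen on an aromatic ring. It produced a 1.4-fold lower number from compound 2 to compound 1 (0.14 log units; within the scatter), a step that does not rise above the scatter of this assay.

Compound 4 `CCOC(=O)c1c(N)sc(C(=O)Nc2ccccc2)c1-c1ccccc1` has not yet been measured in this assay. It differs from compound 3 by hydrogen in place of (cyanomethyl)carbonyl on a nitrogen on an aromatic ring, the same change made at the same kind of place as in the pair already measured. Compound 4 is expected to give 350 nM, with a likely range from 150 nM to 800 nM, because a 1.4-fold lower number from compound 2 to compound 1 (0.14 log units; within the scatter) was small. The expected step is estimated as a 1.4-fold lower number from compound 3 to compound 4 (0.15 log units; within the scatter), again within the scatter.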

Compound 4, half-maximal inhibitory concentration: 8590 nM
The estimate for compound 4 lay 25-fold (1.39 log units) below the measured number; the measured number lies above the stated range.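

In this assay, replacing the (cyanomethyl)carbonyl group with hydrogen on the nitrogen gave an 18-fold higher number from compound 3 to compound 4 (1.24 log units; beyond the scatter), so the size of this change did not carry over from one core to the other: the same change on two cores in this assay, a 1.4-fold lower number (0.14 log units; within the scatter) from compound 2 to compound 1 and an 18-fold higher number (1.24 log units; beyond the scatter) from compound 3 to compound 4, 24-fold (1.38 log units) apart, beyond the scatter of two such steps

On the core of compound 3, the (cyanomethyl)carbonyl group goes with clearly stronger inhibition, whereas on the core of compound 2 its removal does not rise above the scatter. The two cores differ in more than one place, and these pairs do not show which of those differences separates the two results, or how the change would behave on a third core.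

The compounds shown leave open whether the whole (cyanomethyl)carbonyl group is needed on the core of compound 3, or whether a shorter acetyl group on that nitrogen would give a similar number. They also leave open how the same change would read on a core with a carboxylic acid in place of the ethyl ester.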